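Tolerability of amine variants on a shared pyridyl imidazopyridine core

The compounds below may be only part of what the source reports. "The series", "measured", "known", "first", "only" and "open" are said of these compounds alone.

The series keeps one core and varies the substituent on a nitrogen on an aromatic ring. In an ADME assay on THP-1 cells (Homo sapiens) for cytotoxicity (a higher number here means that more compound is tolerated, a lower number that less compound is tolerated), compound 1 `c1ccc(-c2nc3ccccn3c2NCC2CC2)nc1` gives 19400 nM. Compound 2 `c1ccc(-c2nc3ccccn3c2NC2CCNC2)nc1` reaches only a limit of this assay, > 50000 nM. Compound 3 `Fc1cccc(Nc2c(-c3ccccn3)nc3ccccn23)c1` likewise reaches only a limit, > 50000 nM. The measured steps are an at least 2.5-fold higher number from compound 1 to compound 2 (0.41 log units; beyond the scatter) and an at least 2.5-fold higher number from compound 1 to compound 3 (0.41 log units; beyond the scatter), while a step that the two limits leave unreadable from compound 2 to compound 3, because of the limit of > 50000 nM in this assay, at which 2 of the 3 values shown sit.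

Compound 3 therefore stands at the upper limit of this assay, together with compound 2, and only compound 1 gives a number below it.

Compound 4 `COc1ccccc1Nc1c(-c2ccccn2)nc2ccccn12` is not yet measured. It differs from compound 3 by 2-methoxyphenyl in place of 3-fluorophenyl on a nitrogen on an aromatic ring. Within the data shown here, no measured step swaps one aryl group for another on this nitrogen; the two readable steps, from compound 1 to compounds 2 and 3, both move away from cyclopropylmethyl and both end at the limit, and the step from compound 2 to compound 3 is unreadable. An aryl-to-aryl exchange of this kind is expected to give no step beyond the scatter in this assay, so the expected step of a number no higher from compound 3 to compound 4 (the limit leaves the size open) is small. Compound 4 is expected to give 50000 nM, within 25000 nM to 100000 nM, most likely again only as a limit.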

Compound 4, half-maximal cytotoxic concentration: > 50000 nM
Compound 4 ended at the assay's limit; the forecaster's own chance of this, stated with the estimate: 70%; the middle value sits exactly at the limit.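

In this assay compound 4 gives > 50000 nM, which is a limit and not a number. Placing 2-methoxyphenyl in place of cyclopropylmethyl gives an at least 2.5-fold higher number from compound 1 to compound 4 (0.41 log units; beyond the scatter), so a second aryl group on this nitrogen, carrying a hydrogen-bond acceptor that 3-fluorophenyl lacks, ends at the limit alongside 3-fluorophenyl and pyrrolidin-3-yl, and compound 1 is the only one of the four that goes against this pattern. The steps among compound 2, compound 3 and compound 4 cannot be read, because all three values are limits: the limit of > 50000 nM in this assay, at which 3 of the 4 values shown sit.

From the compounds shown here alone, it remains open whether the lower number of compound 1 belongs to cyclopropylmethyl alone or to simple alkyl groups on this nitrogen more widely, which a longer chain such as n-butyl or a cyclohexyl group would address. Going by these compounds, it is also open whether any aryl group on this nitrogen gives a readable number in this assay, for instance a phenyl ring carrying a carboxylic acid or a primary amine.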